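A Smaller Sulfur Group in Place of the Sulfonamide

This account rests on a few compounds, and the source may have more. Where it says the series, first, only, none or still open, it means among the compounds named here.

Compound 1 `CN(C)S(=O)(=O)CCn1c(=N)sc2cc(OC(F)(F)F)ccc21` and compound 2 `N=c1sc2cc(OC(F)(F)F)ccc2n1CCN1CC=C(c2ccccc2)CC1` share the same core. In a functional assay on the whole organism with Rattus norvegicus as the target (on this read-out lower numbers stand for an effect already at smaller amounts and higher numbers for an effect only at larger amounts of compound), compound 1 gives > 10 mg/kg, which is a limit of the assay rather than a number. Compound 1 thus stands at the limit of > 10 mg/kg in this assay, at which 1 of the 2 values shown sits. In this assay compound 2 gives 2.2 mg/kg. Compound 3 `CC[S+]([O-])CCn1c(=N)sc2cc(OC(F)(F)F)ccc21` has not yet been measured; it differs from compound 1 by a group of 4 heavy atoms (2 carbon, 1 oxygen, 1 sulfur; no ring) in place of a group of 6 heavy atoms (2 carbon, 1 nitrogen, 2 oxygen, 1 sulfur; no ring), on a saturated chain carbon, two bonds along the chain from an aromatic nitrogen. For the measured compounds named here, no measured step of this kind exists, so the step from compound 1 to compound 3 is expected to stay within the scatter, a number no higher from compound 1 to compound 3 (the limit leaves the size open). In this assay compound 3 is expected to give 10 mg/kg, between 4 mg/kg and 30 mg/kg.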

Compound 3, dose for half-maximal effect: 1.2 mg/kg
Compound 3: middle estimate off by 8.3-fold (0.92 log units), on the high side; the measured number lies below the stated range.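

On this saturated chain carbon, the group carried there clearly matters in this assay: with the shared core unchanged, replacing dimethylsulfamoyl with the smaller sulfur group gives an at least 8.3-fold lower number from compound 1 to compound 3 (0.92 log units; beyond the scatter). Compound 1 stands at a limit and not at a number, so the full size of this step stays open: the limit of > 10 mg/kg in this assay, at which 1 of the 3 values shown sits.

On these data alone, what remains open is which feature of the new group counts, its sulfur-bound oxygen or its ethyl chain. The matching ethyl sulfone, the ethyl thioether and a longer chain on the sulfur would each test this.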